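A few compounds are considered here, and "the series" means these few. Any claim that something is new, unique, unknown or untested is made for them only; others in the source may bear on it.

Measured so far in a functional assay on K562 cells (Homo sapiens) for antiproliferative activity, read by MTT assay, with a stated time of 48 h; a lower number here means a stronger inhibitor, a higher number a weaker inhibitor:
compound 1 `CN1C(=O)C2(C(C#N)=C(N)Oc3cc4oc(-c5ccccc5)cc(=O)c4c(O)c32)c2ccccc21`: > 50000 nM
compound 2 `CN1C(=O)C2(C(C#N)=C(N)Oc3cc4oc(-c5ccccc5)cc(=O)c4c(O)c32)c2cc(Cl)ccc21`: 4340 nM
compound 3 `CN1C(=O)C2(C(C#N)=C(N)Oc3cc4oc(-c5ccccc5)cc(=O)c4c(O)c32)c2cc(Br)ccc21`: 4100 nM

The value of compound 1 is a limit of this assay, not a number, so compound 1 stands only as an upper boundary of the series (the limit of > 50000 nM in this assay, at which 1 of the 3 values shown sits). From that boundary the two halogen steps are large: an at least 11-fold lower number from compound 1 to compound 2 (1.06 log units; beyond the scatter) and an at least 12-fold lower number from compound 1 to compound 3 (1.08 log units; beyond the scatter). Between the halogens the difference is a 1.1-fold lower number from compound 2 to compound 3 (0.02 log units; within the scatter), within the scatter.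

The next compound is compound 4 `N#CC1=C(N)Oc2cc3oc(-c4ccccc4)cc(=O)c3c(O)c2C12C(=O)N(c1ccccc1)c1ccccc12`. It differs from compound 1 by phenyl in place of methyl on an amide-type nitrogen in a ring. None of the three measured steps bears on this change: each of them alters a halogen on an aromatic carbon and leaves the methyl on the amide-type nitrogen untouched. Starting from a limit, with no comparable step in hand, no direction beyond the scatter can be expected; the step is estimated as an at least 1.2-fold lower number from compound 1 to compound 4 (0.09 log units; that floor lies within the scatter). Compound 4 is therefore expected near 40000 nM, within a wide range from 8000 nM to 200000 nM, with a real chance that this assay again returns only a limit.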

Compound 4, half-maximal inhibitory concentration: > 50000 nM
Compound 4 was reported as a limit (the forecaster's own chance of this, stated with the estimate: 50%); middle value at least 1.2-fold (0.09 log units) away from the limit.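

In this assay compound 1 and compound 4 both return only a limit, so the step between them cannot be read: the limit of > 50000 nM in this assay, at which 2 of the 4 values shown sit.

The compounds shown leave open whether phenyl in place of methyl on the amide-type nitrogen changes this read-out at all, with or without the chloro of compound 2 or the bromo of compound 3.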